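The source may hold more compounds than are shown below. What is called first, only, known or untested is meant among the compounds shown, and "the series" means these compounds.

Measured compounds:
Compound 1 `Cc1cc(Br)cc(C)c1Oc1cc(Nc2ccc(C#N)cc2)c(N)cc1N`: 38400 nM
Compound 2 `COc1ccc(Nc2cc(Oc3c(C)cc(Br)cc3C)c([N+](=O)[O-])cc2[N+](=O)[O-])cc1`: 51200 nM
Compound 3 `Cc1cc(C)c(Oc2cc(Nc3ccc(C#N)cc3)c(N)cc2N)c(C)c1`: 50000 nM

Three compounds have been examined in an ADME assay on H9 cells (Homo sapiens) for cytotoxicity, read by XTT assay, with a stated time of 6 days; on this read-out lower numbers stand for higher toxicity in this test and higher numbers for lower toxicity in this test. Compound 1 gives 38400 nM, and compound 3 gives 50000 nM. The difference between these two is the same change, (methyl in place of bromo on an aromatic carbon), and in this assay it makes a 1.3-fold higher number from compound 1 to compound 3 (0.11 log units; within the scatter). Compound 2 stands at 51200 nM, a number that sits within the scatter of both compound 1 and compound 3, so no order among the three can be read from these values. The difference between the core of compound 2 and the core of compound 1 is not broken down here.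

The unmeasured compound 4 `COc1ccc(Nc2cc(Oc3c(C)cc(C)cc3C)c([N+](=O)[O-])cc2[N+](=O)[O-])cc1` is related to compound 2 by methyl in place of bromo on an aromatic carbon, the same change that separates compound 1 from compound 3, made at the same place. Since that change left the number essentially unmoved in this assay, the step from compound 2 to compound 4 is expected to be small, a 1.2-fold higher number from compound 2 to compound 4 (0.07 log units; within the scatter). Compound 4 is therefore estimated at 60000 nM, with a range from 25000 nM to 150000 nM expected.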

Compound 4, half-maximal cytotoxic concentration: > 59100 nM
Compound 4 ended at the assay's limit (the forecaster's own chance of this, stated with the estimate: 30%); the middle value does not contradict the limit.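

In this assay, compound 4 gives > 59100 nM, which is a limit of the assay and not a number. Methyl in place of bromo on the core of compound 2 gives an at least 1.1-fold higher number from compound 2 to compound 4 (0.06 log units; that floor lies within the scatter), and set beside the same change on the core of compound 1, the two steps read: the same change on two cores in this assay, a 1.3-fold higher number (0.11 log units; within the scatter) from compound 1 to compound 3 and an at least 1.1-fold higher number (0.06 log units; that floor lies within the scatter) from compound 2 to compound 4; the limit leaves it open whether they differ The change from 4-bromo-2,6-dimethylphenyl to 2,4,6-trimethylphenyl thus shows no sign of behaving differently on the two cores, but this does not show that the two steps are equal, and two cores, one of them ending at a limit, give no general rule for the series.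

The compounds shown carry only bromo or methyl at this place, and what an amine, a carboxylic acid or a longer chain would do there in this assay stays open. From the compounds shown here alone, the core of compound 1 and the core of compound 2 differ in more than one place, and what each of those differences does on its own also stays open.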